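The source may report more compounds than this note shows. Statements on the series, on what has been measured and on what is new or still open speak of the compounds shown alone.

Values in a functional assay on MGC-803 cells (Homo sapiens) for antiproliferative activity, read by MTT assay, with a stated time of 72 h (on this read-out lower numbers stand for stronger inhibition and higher numbers for weaker inhibition), are as follows:
- compound 1 `O=C(COc1ccc(C(=O)/C=C/c2ccc(F)c(F)c2)cc1)N[C@H]1CCOC1=O` gives > 64000 nM (a limit)
- compound 2 `CC(C)c1ccc(/C=C/C(=O)c2ccc(OCC(=O)N[C@H]3CCOC3=O)cc2)cc1` gives 16800 nM
- compound 3 `O=C(CNc1ccc(Cl)cc1Cl)N[C@H]1CCOC1=O` gives > 64000 nM (a limit)

Compound 3 has no exact number, since it sits at the limit of > 64000 nM in this assay, at which 2 of the 3 values shown sit, and so marks only a limit. Compound 4 `O=C(CNc1ccc(Cl)cc1)N[C@H]1CCOC1=O` differs from it by hydrogen in place of chloro on an aromatic carbon. Among the compounds with values here, the one measured step, an at least 3.8-fold lower number from compound 1 to compound 2 (0.58 log units; beyond the scatter), changes a different group in different compounds, and no measured step removes a chloro. A step beyond the scatter is therefore not expected in this assay, and no direction can be favoured. The estimated change is a number no higher from compound 3 to compound 4 (the limit leaves the size open). For compound 4 the expected value is 64000 nM, with an estimated range from 30000 nM to 130000 nM.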

Compound 4, half-maximal inhibitory concentration: > 64000 nM
Compound 4: a limit, no number (the forecaster's own chance of this, stated with the estimate: 75%); the middle value lies on the limit itself.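

Compound 3 and compound 4 are both limits rather than numbers, so the step between them cannot be read: the limit of > 64000 nM in this assay, at which 3 of the 4 values shown sit.

The compounds shown leave open whether hydrogen in place of chloro on an aromatic carbon changes inhibition at all.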